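The source may hold more compounds than are shown below. What is called first, only, known or untested is meant among the compounds shown, and "the series" means these compounds.

Of the compounds shown here, three that share one core have been measured in an ADME assay on HEK293 cells (Homo sapiens) for cytotoxicity, read by MTT assay, with a stated time of 48 h; on this read-out lower numbers stand for stronger inhibition and higher numbers for weaker inhibition. Compound 1 `Cc1ccc(S(=O)(=O)/N=C(/CCNC2=CC(=O)c3ccccc3C2=O)Nc2ccc(Cl)cc2)cc1` gives 65400 nM. Compound 2 `Cc1ccc(S(=O)(=O)/N=C(/CCNC2=CC(=O)c3ccccc3C2=O)Nc2ccc(F)cc2)cc1` gives 55100 nM. Compound 3 `Cc1ccc(S(=O)(=O)/N=C(/CCNC2=CC(=O)c3ccccc3C2=O)Nc2ccccc2[N+](=O)[O-])cc1` gives 69600 nM, the highest of the three numbers, although its gaps to the other two lie within the scatter: a 1.1-fold higher number from compound 1 to compound 3 (0.03 log units; within the scatter) and a 1.3-fold higher number from compound 2 to compound 3 (0.10 log units; within the scatter). Likewise a 1.2-fold lower number from compound 1 to compound 2 (0.07 log units; within the scatter). So far, exchanging the group on the amine nitrogen has not moved the number beyond the scatter.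

Compound 4 `Cc1ccc(S(=O)(=O)/N=C(/CCNC2=CC(=O)c3ccccc3C2=O)Nc2ccccc2I)cc1` differs from compound 3 by iodo in place of nitro on an aromatic carbon. The three measured steps all concern changes on this same aromatic ring, and each of them stayed within the scatter. Nothing in them points to a shift in this assay beyond the scatter in either direction, so compound 4 is expected to give a number close to that of compound 3. The expected step is a 1.1-fold lower number from compound 3 to compound 4 (0.03 log units; within the scatter). Compound 4 is estimated at 65000 nM, with a range from 30000 nM to 140000 nM.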

Compound 4, half-maximal inhibitory concentration: 49400 nM
Beside the measured number, compound 4's estimate is 1.3-fold (0.12 log units) above it, within the range that was stated.
By their numbers in this assay, from the lowest: compounds 4, 2, 1 and 3 (each within the scatter of the next).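

Iodo in place of nitro on this aromatic carbon, ortho to a large group, gives a 1.4-fold lower number from compound 3 to compound 4 (0.15 log units; within the scatter) in this assay. Going by these compounds alone, this is the first direct exchange at this position: a single iodine atom with no hydrogen-bond acceptors replaces a group of three heavy atoms with two acceptors, and the step stays within the scatter. The wider exchanges of the whole aryl group, a 1.1-fold lower number from compound 2 to compound 4 (0.05 log units; within the scatter) and a 1.3-fold lower number from compound 1 to compound 4 (0.12 log units; within the scatter), also stay within it, and no measurement here explains why the numbers sit so close together.

Going by these compounds, whether an amine or a carboxylic acid on this aromatic carbon would move the number beyond the scatter remains open. So does whether a longer chain elsewhere on the shared core would do so.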